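A few compounds are considered here, and "the series" means these few. Any claim that something is new, unique, unknown or untested is made for them only; others in the source may bear on it.

The series shares a common core and differs only in the group carried on a saturated chain carbon bound to an aromatic carbon and a saturated chain carbon. In a functional assay on CHO cells for antagonist activity at prostaglandin E2 receptor EP3 subtype (Homo sapiens), read by cAMP accumulation (a higher number here means a weaker inhibitor, a lower number a stronger inhibitor), compound 1 `CC(C)C(/C=C1/CCNC1=O)c1ccc(-c2ccc3cccc(F)c3c2)[nH]c1=O` gives 8.1 nM. Compound 2 `CC(C)C(Nc1nnc[nH]1)c1ccc(-c2ccc3cccc(F)c3c2)[nH]c1=O` gives 185 nM in this assay, and compound 3 `Cc1c[nH]c(C(c2ccc(-c3ccc4cccc(F)c4c3)[nH]c2=O)C(C)C)n1` gives 36 nM. Compound 3 thus stands second highest of the three numbers: the step of a 4.4-fold higher number from compound 1 to compound 3 (0.65 log units; beyond the scatter) lies beyond the scatter, as does the step of a 5.1-fold lower number from compound 2 to compound 3 (0.71 log units; beyond the scatter).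

Compound 4 `CC(C)C(Cc1nnc[nH]1)c1ccc(-c2ccc3cccc(F)c3c2)[nH]c1=O` is the next step from compound 3, with (4H-1,2,4-triazol-3-yl)methyl in place of 4-methyl-1H-imidazol-2-yl on a saturated chain carbon bound to an aromatic carbon and a saturated chain carbon. Among the compounds with values here, two measured steps bear on this. Replacing the non-aromatic ring of compound 1 by the (4H-1,2,4-triazol-3-yl)amino group gave a 23-fold higher number from compound 1 to compound 2 (1.36 log units; beyond the scatter), a large loss, while replacing it by the 4-methyl-1H-imidazol-2-yl group gave only a 4.4-fold higher number from compound 1 to compound 3 (0.65 log units; beyond the scatter). Compound 4 carries the same triazole ring as compound 2 but attached through a methyl rather than an amino link, so it is expected to fall between compound 3 and compound 2 in this assay, with a higher number than compound 3 beyond the scatter: the expected step is a 2.8-fold higher number from compound 3 to compound 4 (0.44 log units; beyond the scatter). The estimate for compound 4 is 100 nM, in the range 35 nM to 300 nM.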

Compound 4, half-maximal inhibitory concentration: 17 nM
Beside the measured number, compound 4's estimate is 5.9-fold (0.77 log units) above it; the whole stated range lies above it.
By their numbers in this assay, from the lowest: compound 1; then compound 4; then compound 3; then compound 2.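

With the triazole ring held constant, changing the amino link to a methyl link gives an 11-fold lower number from compound 2 to compound 4 (1.04 log units; beyond the scatter) in this assay, so at this position the link to the ring matters greatly, which compounds differing in both ring and link could not show. The (4H-1,2,4-triazol-3-yl)methyl group also improves on 4-methyl-1H-imidazol-2-yl, with a 2.1-fold lower number from compound 3 to compound 4 (0.33 log units; beyond the scatter) in this assay, a modest step that lies beyond the scatter. It does not fully match the non-aromatic ring group, since a 2.1-fold higher number from compound 1 to compound 4 (0.32 log units; beyond the scatter) remains, but that modest step shows that a five-membered aromatic ring with three hetero atoms need not bring the large loss seen for compound 2.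

The compounds shown leave open how a longer chain, an ether oxygen link or a methyl group on the triazole ring would behave in this assay, and whether the methyl link would help the imidazole ring as it does the triazole ring. Nothing available here explains why the two links differ so widely.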